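Shrinking the Amide Side Chain: Isobutyl to Cyclopropyl

The source may hold more compounds than are shown below. What is called first, only, known or untested is meant among the compounds shown, and "the series" means these compounds.

Measured compounds:
compound 1, `CC(C)C(=O)Nc1sc2c(c1C#N)CCCC2`, 3400 nM
compound 2, `CC(C)CC(=O)Nc1sc2c(c1C#N)CCCC2`, 1900 nM

Both compounds were tested in a functional assay on RKE cells for antagonist activity at Vasoactive intestinal polypeptide receptor 1 (Rattus norvegicus), read by HTRF and cAMP accumulation, with stated times of 10 min and 30 min; on this read-out higher numbers stand for weaker inhibition and lower numbers for stronger inhibition. Compound 2 gives 1900 nM, and compound 1 gives 3400 nM; the step of a 1.8-fold lower number from compound 1 to compound 2 (0.25 log units; within the scatter) lies within the scatter, so the two numbers cannot be told apart with confidence. Compound 2 is the nearest neighbour of the new compound 3, `N#Cc1c(NC(=O)C2CC2)sc2c1CCCC2`, which has not yet been measured.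

The change from compound 2 to compound 3 is cyclopropyl in place of isobutyl on a carbonyl carbon. Going by the values given here, the only measured step that touches the same place, a 1.8-fold lower number from compound 1 to compound 2 (0.25 log units; within the scatter), swapped one small branched chain for another and stayed within the scatter. Nothing measured here speaks to a three-membered ring, so the safest expectation is that the new change also stays within the scatter, with no clear direction.

For compound 3 the expected step is a 1.3-fold higher number from compound 2 to compound 3 (0.12 log units; within the scatter), and compound 3 is estimated to give 2500 nM in this assay, with a likely range from 1000 nM to 7000 nM.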

Compound 3, half-maximal inhibitory concentration: 2700 nM
Estimate against measurement, compound 3: 1.1-fold (0.03 log units) below; the measured number falls inside the stated range.
By their numbers in this assay, from the lowest: compounds 2, 3 and 1 (each within the scatter of the next).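

Going by these compounds alone, putting a ring on a carbonyl carbon, where the earlier compounds carried only open chains, leaves the result in this assay within the scatter. This holds against isobutyl (a 1.4-fold higher number from compound 2 to compound 3 (0.15 log units; within the scatter)) and against isopropyl (a 1.3-fold lower number from compound 1 to compound 3 (0.10 log units; within the scatter)), so cyclopropyl, a three-membered ring of carbon only, joins the two open chains in a group of side chains that cannot be told apart here, and none of the three compounds can be ranked above another. No measurement is available to explain why these side chains read alike.

As far as these compounds go, all three side chains are small and made of carbon only, so it remains open whether any group at this place can move the number beyond the scatter, in either direction. An amine, a carboxylic acid, a longer chain or a phenyl ring on the same carbonyl carbon would put that question to the test, while the effect of changes to the shared core lies outside what these three compounds can show.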